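Removing a Dimethylamino Group: What Solubility to Expect

A few compounds are considered here, and "the series" means these few. Any claim that something is new, unique, unknown or untested is made for them only; others in the source may bear on it.

Compound 2 `COc1ccc(F)cc1CNCCCNc1ccnc2cc(Oc3cccc(N(C)C)c3)ccc12` has the higher solubility of the two measured compounds: in a physicochemical assay for solubility, with a stated time of 18 h, at pH 7.4 (on this read-out higher numbers stand for higher solubility and lower numbers for lower solubility), compound 2 gives 14500 nM. Within the data shown here, its only measured neighbour is compound 1 `COc1ccc(F)cc1CNCCCNc1ccnc2cc(Cc3ccc(C#N)cc3)ccc12`, which in this assay gives 4200 nM; the single measured step is a 3.5-fold higher number from compound 1 to compound 2 (0.54 log units; beyond the scatter). Compound 3 `COc1ccc(F)cc1CNCCCNc1ccnc2cc(Oc3ccccc3)ccc12` differs from compound 2 in one place: hydrogen in place of dimethylamino on an aromatic carbon. The measured step swaps the whole side group at once, 4-cyanobenzyl for 3-(dimethylamino)phenoxy. It therefore does not show how much of that step comes with the dimethylamino group alone and how much with the rest of the side group. Among the measured compounds shown here, no measured step bears directly on the change from compound 2 to compound 3, and the expectation must stay loose. A step of modest size is expected, more likely toward lower solubility than higher, though a result within the scatter would not be surprising; the expected step is a 2.1-fold lower number from compound 2 to compound 3 (0.32 log units; beyond the scatter). Compound 3 is therefore expected to give 7000 nM in this assay, with a range from 2500 nM to 25000 nM.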

Compound 3, solubility: 14500 nM
For compound 3 the middle estimate is 2.1-fold (0.32 log units) below the measured one, within the range that was stated.
By their numbers in this assay, from the lowest: compound 1; then compounds 2 and 3 (each within the scatter of the next).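

Removing the dimethylamino group from this aromatic carbon leaves the solubility number in this assay in place, with no change at the digits printed from compound 2 to compound 3 (within the scatter) in the measured step. The step up from compound 1 also survives without that group: there is a 3.5-fold higher number from compound 1 to compound 3 (0.54 log units; beyond the scatter) and it matches in size the earlier 3.5-fold higher number from compound 1 to compound 2 (0.54 log units; beyond the scatter) so among these three compounds the gap to compound 1 appears with a phenoxy side group whether or not the dimethylamino group is present. Nothing available here explains why the number stays where it does.

Among these compounds, what remains open is whether this flat result holds for other groups on the same ring, such as a methoxy group, a primary amine or a carboxylic acid, since dimethylamino is the only group compared with hydrogen there. The side-group swap also changes several things at once, so these compounds cannot separate the part played by the nitrile from that of the link to the core, which a plain benzyl group would help to address.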